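Hydroxy replaces a large group at the assay limit

This account rests on a few compounds, and the source may have more. Where it says the series, first, only, none or still open, it means among the compounds named here.

Compound 1 `COc1ccc(-c2c(C)nc3c(N4CC[C@@H](NC(=O)c5ccccc5)C4)cc(C)nn23)cc1OC` gives > 95% in an ADME assay on microsomes from liver (Homo sapiens) for metabolic stability, read by LC-MS, with NADPH named in the record, with a stated time of 60 min, tested at 1 uM, in the absence of a further agent (on this read-out lower numbers stand for a less stable compound and higher numbers for a more stable compound), a limit and not a number. Compound 2 `COc1ccc(-c2c(C)nc3c(N4CC[C@@H](NS(=O)(=O)C(C)C)C4)cc(C)nn23)cc1OC` gives the limit > 95%. Compound 3 `COc1ccc(-c2c(C)nc3c(N4CC[C@@H](NS(=O)(=O)c5ccc(C)cc5)C4)cc(C)nn23)cc1OC` also gives a limit, > 95%, so it has no exact value.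

Compound 4 `COc1ccc(-c2c(C)nc3c(N4CC[C@@H](O)C4)cc(C)nn23)cc1OC` differs from compound 3 in one place, with hydroxy in place of ((4-methylphenyl)sulfonyl)amino on a saturated ring carbon.

The closest evidence is a step that the two limits leave unreadable from compound 1 to compound 3, alongside a step that the two limits leave unreadable from compound 1 to compound 2 and a step that the two limits leave unreadable from compound 2 to compound 3. These three steps have no readable size, and none of them removes the whole group that compound 4 loses. All that can be carried forward is the limit of > 95% in this assay, at which 3 of the 3 values shown sit, which holds across the three side groups on the shared core. Compound 4 keeps that core, so in this assay the expected change is a number at least 3 percentage points lower from compound 3 to compound 4 (that floor lies within the scatter), with no shift beyond the usual scatter anticipated. For compound 4 the estimated value is 92%, with an expected range from 78% to 100%.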

Compound 4, percent of the compound remaining: > 95%
Compound 4 gave a limit, no number (the forecaster's own chance of this, stated with the estimate: 55%); middle value at least 3 percentage points away from the limit.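

No new step can be read, since compound 4, like compounds 1, 2 and 3, gives only a limit in this assay: the limit of > 95% in this assay, at which 4 of the 4 values shown sit.

The compounds shown leave open how far their true stabilities differ and which change to the shared core's side group would lower the percent remaining.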